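Acetoxy for benzamido on the saturated ring

The source may hold more compounds than are shown below. What is called first, only, known or untested is meant among the compounds shown, and "the series" means these compounds.

Compound 2 (`O=C(NC1CCC(CN2CCN(c3cc(=O)c4cc(C(F)(F)F)cc([N+](=O)[O-])c4s3)CC2)CC1)c1ccccc1`) gives 90.6% in an ADME assay on cells (Hepatocyte, Mus musculus) for metabolic stability, with a stated time of 30 min (a higher number here means that more of the compound is left, a lower number that less of the compound is left), and holds the second highest of three numbers. Compound 1 (`NC1CCC(CN2CCN(c3cc(=O)c4cc(C(F)(F)F)cc([N+](=O)[O-])c4s3)CC2)CC1`) stands higher at 107% in this read-out, and compound 3 (`O=c1cc(N2CCN(CC3CCCCC3)CC2)sc2c(NO)cc(C(F)(F)F)cc12`) stands lower at 47.8% in the same read-out.

Compound 4 (`CC(=O)OC1CCC(CN2CCN(c3cc(=O)c4cc(C(F)(F)F)cc([N+](=O)[O-])c4s3)CC2)CC1`) has not yet been measured. It carries acetoxy in place of benzamido on a saturated ring carbon.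

Within the data shown here, one measured step bears on this change, and it is modest (a number 16.4 percentage points lower from compound 1 to compound 2 (beyond the scatter)). It involves the group on the same ring carbon, but it adds benzoyl to an amine nitrogen and does not replace that nitrogen. Among the measured compounds shown here, compound 3 has no group on that ring carbon and also differs on the core, so it gives no clean step. For the measured compounds named here, no measured compound carries acetoxy, so the evidence is thin and the range must stay wide.

Going by the values given here, compound 2 at 90.6% already lies near the top of the measured numbers, so a fall is expected, probably larger than the one measured step. The expected change is (a number 28.6 percentage points lower from compound 2 to compound 4 (beyond the scatter)). For compound 4 the estimated value is 62% in this assay, with an expected range from 30% to 90% for repeat measurements.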

Compound 4, percent of the compound remaining: 0%
Compound 4: middle estimate off by 62 percentage points, on the high side; measured number outside the range, below it.
By their numbers in this assay, from the lowest: compound 4; then compound 3; then compound 2; then compound 1.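

On the saturated ring carbon, the group changes the result in this assay far more than the earlier step suggested: a number 90.6 percentage points lower from compound 2 to compound 4 (beyond the scatter) is large, while a number 16.4 percentage points lower from compound 1 to compound 2 (beyond the scatter) is only modest. Compound 1 with amino (107%) and compound 2 with benzamido (90.6%) both stay high, so among the three compounds with this core and a group on that carbon, only acetoxy brings the read-out down, with a number 107 percentage points lower from compound 1 to compound 4 (beyond the scatter) as the largest step in the series. The compounds shown offer no measurement that explains this fall.

Going by these compounds, it remains open whether the loss goes with acetoxy as a whole or with an oxygen atom on that ring carbon; a hydroxyl, a methyl ether or an acetamido group at the same place would separate these readings. On these data alone, it is also open whether a larger group such as benzoyloxy would follow acetoxy or stay closer to benzamido on the same core.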